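A few compounds are considered here, and "the series" means these few. Any claim that something is new, unique, unknown or untested is made for them only; others in the source may bear on it.

Compound 1, `COc1ccc(-c2cc3cc(C)ccc3c(N3CCN(C)CC3)n2)cc1`, gives 7410 nM in a functional assay on A549 cells (Homo sapiens) for cytotoxicity, read by sulforhodamine B assay; a lower number here means a stronger inhibitor, a higher number a weaker inhibitor.
Compound 2, `Cc1ccc2c(N3CCN(C)CC3)nc(-c3ccc(Cl)cc3)cc2c1`, gives 3190 nM in this assay.
Compound 3, `CN1CCN(c2nc(-c3ccc(Cl)cc3)cc3c(N(C)C)cccc23)CC1`, gives 7450 nM in this assay.

Compound 1 and compound 2 share the same core and differ in one place only: methoxy in place of chloro on an aromatic carbon. That single change made a step of a 2.3-fold higher number from compound 2 to compound 1 (0.37 log units; beyond the scatter), so the methoxy compound is the weaker inhibitor of the two in this assay.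

Compound 3 carries a different core from compound 2, and the difference between the two cores is not broken down here. What the values show is that compound 3 gives a higher number than compound 2 in this assay, while the numbers of compound 3 and compound 1 lie within the usual scatter of each other, so no order can be read between those two.

Compound 4, `COc1ccc(-c2cc3c(N(C)C)cccc3c(N3CCN(C)CC3)n2)cc1`, has not yet been measured. It differs from compound 3 by methoxy in place of chloro on an aromatic carbon. This is the same change that led from compound 2 to compound 1: the group that leaves, the group that enters and the place where it sits read the same word for word. Because the earlier step was a 2.3-fold higher number from compound 2 to compound 1 (0.37 log units; beyond the scatter), a step of similar size is expected here, namely a 2.1-fold higher number from compound 3 to compound 4 (0.33 log units; beyond the scatter), with compound 3 as the starting point. On that basis compound 4 is expected to give about 16000 nM in this assay, most likely between 7500 nM and 35000 nM.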

Compound 4, half-maximal inhibitory concentration: 1820 nM
The estimate for compound 4 lay 8.8-fold (0.94 log units) above the measured number; measured number below the stated range.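

The new step is a 4.1-fold lower number from compound 3 to compound 4 (0.61 log units; beyond the scatter) in this assay, so the change from 4-chlorophenyl to 4-methoxyphenyl leaves compound 4 the stronger inhibitor of its pair, whereas on the other core the same change leaves compound 1 the weaker one. Set side by side, the two steps run in opposite directions and do not agree within the usual scatter: the same change on two cores in this assay, a 2.3-fold higher number (0.37 log units; beyond the scatter) from compound 2 to compound 1 and a 4.1-fold lower number (0.61 log units; beyond the scatter) from compound 3 to compound 4, 9.5-fold (0.98 log units) apart, beyond the scatter of two such steps This shows that, in this series, the swap cannot be carried from one core to another as a fixed step, or even with a fixed direction, although two pairs cannot show which feature of the cores sets the outcome or what a third core would do.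

Among the compounds shown, only chloro and methoxy occupy this place on the phenyl ring, so it remains open how a hydroxyl group, an amine or a longer ether chain would read there on either core. From the compounds shown here alone, it also remains open whether the opposite steps belong to the two cores as wholes or to one part of them, which only further pairs that differ in a single place could settle.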